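A few compounds are considered here, and "the series" means these few. Any claim that something is new, unique, unknown or untested is made for them only; others in the source may bear on it.

Values so far in an ADME assay on HEK293 cells (Homo sapiens) for cytotoxicity, read by ATP content, with a stated time of 6 h (a lower number here means that less compound is tolerated, a higher number that more compound is tolerated), each one a limit and not a number:

- Compound 1 `CCCCNc1nc(N)nc2ccn(Cc3ccccn3)c12` gives > 24000 nM as a limit
- Compound 2 `Cc1cnc(CNc2nc(N)nc3ccn(Cc4ccccn4)c23)o1` gives > 24000 nM as a limit
- Compound 3 `Nc1nc(NCc2nccs2)c2c(ccn2Cc2ccccn2)n1` gives > 24000 nM as a limit

Among the compounds with values here, compound 3 therefore has no exact number, and the series so far offers only the limit of > 24000 nM in this assay, at which 3 of the 3 values shown sit, as its common result.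

The next compound is compound 4 `CC(C)c1cc(CNc2nc(N)nc3ccn(Cc4ccccn4)c23)no1`, in which 5-isopropyl-1,2-oxazol-3-yl replaces 1,3-thiazol-2-yl on a saturated chain carbon bound to a nitrogen on an aromatic ring. Counted out, the change reads 5-isopropyl-1,2-oxazol-3-yl in place of 1,3-thiazol-2-yl on a saturated chain carbon bound to a nitrogen on an aromatic ring and nothing else in the structure differs.

Three measured changes sit at this same place: a step that the two limits leave unreadable from compound 1 to compound 2 and a step that the two limits leave unreadable from compound 1 to compound 3 and a step that the two limits leave unreadable from compound 2 to compound 3 all give no size to carry over. Compound 3 at > 24000 nM is the starting point for this expectation, and that value is a limit. No step beyond the scatter is expected in this assay and no direction can be given. The expected step is a step that the limit leaves unreadable from compound 3 to compound 4 and it is only an estimate. For compound 4 the estimated value is 26000 nM with an expected range from 14000 nM to 50000 nM and a report of the limit alone is the likeliest outcome.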

Compound 4, half-maximal cytotoxic concentration: > 24000 nM
Compound 4: a limit, no number (the forecaster's own chance of this, stated with the estimate: 85%); the middle value is on the limit's open side.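

No step can be read among compounds 1, 2, 3 and 4 in this assay, because each result is only a limit: the limit of > 24000 nM in this assay, at which 4 of the 4 values shown sit.

The compounds shown leave open the exact value of each one in this assay, and so whether changing the group at this place makes any difference.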